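Adding phenoxy to the benzyl group of compound 2

A few compounds are considered here, and "the series" means these few. Any claim that something is new, unique, unknown or untested is made for them only; others in the source may bear on it.

In a functional assay on HCT-116 cells (Homo sapiens) for antiproliferative activity, read by WST assay, with a stated time of 72 h (a higher number here means a weaker inhibitor of growth, a lower number a stronger inhibitor of growth), compound 1 (`O=C(NO)c1cnc(N2C[C@@H]3[C@H](C2)[C@H]3NS(=O)(=O)c2cccs2)nc1`) gives > 10000 nM, which is a limit and not a number. For the measured compounds named here, compound 2 (`O=C(NO)c1cnc(N2C[C@@H]3[C@H](C2)[C@H]3NCc2ccccc2)nc1`) gives 120 nM, the only true number so far. Compound 3 (`O=C(NO)c1cnc(N2C[C@@H]3[C@H](C2)[C@H]3NCc2ccc(Oc3ccccc3)cc2)nc1`) has phenoxy in place of hydrogen on an aromatic carbon, para to a large group (phenoxy in place of hydrogen on an aromatic carbon). Going by the values given here, the single measured step, a benzyl swap on the same amine nitrogen, was large: an at least 83-fold lower number from compound 1 to compound 2 (1.92 log units; beyond the scatter). That step did not test this ring, so only a small change is expected, within the scatter: a 1.2-fold lower number from compound 2 to compound 3 (0.08 log units; within the scatter). For compound 3 the estimate is 100 nM, with an expected range of 30 nM to 400 nM.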

Compound 3, concentration for 50% growth inhibition: 120 nM
Beside the measured number, compound 3's estimate is 1.2-fold (0.08 log units) below it; the measured number falls inside the stated range.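

In this assay, there is no change at the digits printed from compound 2 to compound 3 (within the scatter) even though phenoxy adds a whole extra aromatic ring to the benzyl group. For the compounds shown here, the earlier step changed only the group on the amine nitrogen, so this is the first sign that the benzyl ring can carry a large addition at this position without losing growth inhibition. Nothing measured here explains why the number holds. Going by these compounds, whether a carboxylic acid or an amine on the same ring carbon would also leave the number in place remains open.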